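The source may hold more compounds than are shown below. What is called first, only, known or untested is meant among the compounds shown, and "the series" means these compounds.

Measured compounds:
Compound 2 `CN(C)CCn1cc(S(=O)(=O)c2cc(Cl)cc(Cl)c2)c2cccnc21`: 28 nM in a functional assay on HeLa cells for agonist activity at 5-hydroxytryptamine receptor 6 (Homo sapiens), read by immunoassay; a lower number here means that less compound is needed, a higher number that more compound is needed for the effect
Compound 3 `NCCn1cc(S(=O)(=O)c2cc(Cl)cc(Cl)c2)c2cccnc21`: 35 nM in this assay
Compound 1 `NCCn1cc(S(=O)(=O)c2cccc(C(F)(F)F)c2)c2cccnc21`: 110 nM in this assay

Compound 2 has the lowest number of the three in this assay. Within the data shown here, compound 3 sits closest to it, and the only single-point step in this set, a 1.3-fold higher number from compound 2 to compound 3 (0.10 log units; within the scatter), lies within the scatter. Among the measured compounds shown here, compound 1 is furthest away, beyond the scatter; it differs from compound 3 only in the group on the sulfonyl sulfur, but no single step between compound 1 and compound 3 is computed here, so their two values simply show that the group on the sulfonyl sulfur can shift the number.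

The step to compound 4 `CN(C)CCn1cc(S(=O)(=O)c2ccc(Cl)s2)c2cccnc21` changes exactly that group: 5-chlorothiophen-2-yl in place of 3,5-dichlorophenyl on a sulfonyl sulfur. For the measured compounds named here, the measured step from compound 2 to compound 3 does not touch this position, so it gives no guide, and no measured pair matches the exchange of a six-membered ring for a five-membered one. The expectation is therefore cautious: a modest rise in the number, with a wide range, a 2.1-fold higher number from compound 2 to compound 4 (0.33 log units; beyond the scatter). Compound 4 is estimated to give 60 nM in this assay, between 20 nM and 200 nM.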

Compound 4, half-maximal effective concentration: 32 nM
Compound 4: the middle estimate sits 1.9-fold (0.27 log units) above what was measured; the measured number falls inside the stated range.
By their numbers in this assay, from the lowest: compounds 2, 4 and 3 (each within the scatter of the next); then compound 1.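

In this assay, putting 5-chlorothiophen-2-yl in place of 3,5-dichlorophenyl on the sulfonyl sulfur gives a 1.1-fold higher number from compound 2 to compound 4 (0.06 log units; within the scatter), so this exchange leaves no change that can be told apart from the scatter. The earlier compounds shown here only hinted that the group on the sulfonyl sulfur can matter, whereas this single-place step shows that a five-membered aromatic ring with 1 hetero atom and 6 heavy atoms can stand here in place of a six-membered aromatic ring of carbon only with 8 heavy atoms, with no measurable penalty in this assay. Nothing measured here explains why the two groups read alike.

The compounds shown leave open what the chlorine on the thiophene contributes, which a plain thiophen-2-yl or a 5-methylthiophen-2-yl group on the sulfonyl sulfur would help to settle. They also leave open whether amino in place of dimethylamino on the chain, which gave a 1.3-fold higher number from compound 2 to compound 3 (0.10 log units; within the scatter) with the 3,5-dichlorophenyl group, would behave the same way with 5-chlorothiophen-2-yl on the sulfonyl sulfur.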